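This account rests on a few compounds, and the source may have more. Where it says the series, first, only, none or still open, it means among the compounds named here.

Measured in an ADME assay on THP-1 cells (Homo sapiens) for cytotoxicity; on this read-out lower numbers stand for higher toxicity in this test and higher numbers for lower toxicity in this test:
Compound 1 `COC(=O)Nc1sc2c(c1C(=O)Nc1ccc(OC)cc1)CCCCC2`: > 50000 nM
Compound 2 `O=C(Nc1ccc(C(F)(F)F)cc1)c1c(NC(=O)C(F)(F)F)sc2c1CCCCC2`: 17200 nM

The entry of compound 1 at > 50000 nM is a limit of the assay and not a number. Among the compounds with values here, compound 2, at 17200 nM, therefore holds the only true number so far in this assay, and it cannot be placed exactly against its one companion. The next compound to be tested is compound 3 `Cc1ccc(NC(=O)c2c(NC(=O)C(F)(F)F)sc3c2CCCCC3)cc1`. It keeps the shared core of compound 2 and puts methyl in place of trifluoromethyl on an aromatic carbon, para to a large group: methyl in place of trifluoromethyl on an aromatic carbon.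

Within the data shown here, no measured step shows what this exchange does, so the expectation rests on very little. In this assay, no step beyond the scatter is expected, with only a slight lean toward higher numbers. Among the measured compounds shown here, that lean rests on the limit recorded for compound 1, > 50000 nM, the sole other reading. The estimate is a 1.4-fold higher number from compound 2 to compound 3 (0.14 log units; within the scatter). For compound 3 the expected value is 24000 nM, with an estimated range from 10000 nM to 50000 nM.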

Compound 3, half-maximal cytotoxic concentration: > 50000 nM
Compound 3: no number, only a limit (the forecaster's own chance of this, stated with the estimate: 25%); at least 2.0-fold (0.31 log units) between middle value and limit.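

Methyl in place of trifluoromethyl on an aromatic carbon, para to a large group, gives the first step read at this position in this assay, and it is a clear one: an at least 2.9-fold higher number from compound 2 to compound 3 (0.46 log units; beyond the scatter). Compound 3 reads > 50000 nM, which is a limit of the assay and not a number, so the change moves the compound out of the measurable range and the step has a floor but no upper end. Compound 2, with 4-(trifluoromethyl)phenyl, thus remains the only compound shown that gives a true number, and the exchange of this one group is enough to separate it from that limit: the limit of > 50000 nM in this assay, at which 2 of the 3 values shown sit.

As far as these compounds go, how far compound 3 lies beyond its limit stays unknown, and so does the full size of the step from 4-(trifluoromethyl)phenyl to 4-methylphenyl. From the compounds shown here alone, it also remains open whether a chlorine atom or a nitrile on this aromatic carbon would keep the number seen for compound 2 or reach the limit seen for compound 3, and whether the same exchange would give a step of this kind with the rest of the molecule changed.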